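A few compounds are considered here, and "the series" means these few. Any claim that something is new, unique, unknown or untested is made for them only; others in the source may bear on it.

In a functional assay on the whole organism for inhibition, with Chenopodium ficifolium as the target, with a stated time of 72 h, tested at 10 mg/L (on this read-out lower numbers stand for less inhibition of growth and higher numbers for more inhibition of growth at the one concentration tested), compound 1 `COc1cc(SC)nc(NC(=S)NC(=O)c2c(-c3ccc(Cl)cc3Cl)noc2C)n1` gives -8.31%, the lowest of the three numbers available. The other two compounds carry a different arrangement of the pyrimidine portion: compound 2 `Cc1onc(-c2ccc(Cl)cc2Cl)c1C(=O)/N=c1/nc2nc(Cl)cc(C)n2s1` gives 18.6% in this assay, and compound 3 `COc1cc(OC)n2s/c(=N\C(=O)c3c(-c4ccc(Cl)cc4Cl)noc3C)nc2n1` gives 28.9%, so both sit well above compound 1, and the gap to compound 3 is the widest. No pair among these three differs in only one place, so no single structural step has a measured effect attached to it.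

Compound 4 `Cc1cc(O)nc(NC(=S)NC(=O)c2c(-c3ccc(Cl)cc3Cl)noc2C)n1` is the untested neighbour of compound 1. The change is 4-hydroxy-6-methylpyrimidin-2-yl in place of 4-methoxy-6-(methylsulfanyl)pyrimidin-2-yl on an amide-type nitrogen. Nothing in the measured set shows what such an exchange on the thiourea side does to growth inhibition; the fused compounds 2 and 3 alter the core as well and cannot serve as a guide. For that reason the step from compound 1 to compound 4 is expected to be small, a number 10.3 percentage points higher from compound 1 to compound 4 (beyond the scatter), with no change beyond the scatter as the central case. Compound 4 is therefore estimated at 2% in this assay, within a range from -15% to 22%.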

Compound 4, percent growth inhibition at one concentration: -5.86%
The estimate for compound 4 lay 7.9 percentage points above the measured number, and the stated range covers the measured number.
By their numbers in this assay, from the lowest: compounds 1 and 4 (each within the scatter of the next); then compound 2; then compound 3.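

In this assay the series now has its first exchange in a single place: 4-hydroxy-6-methylpyrimidin-2-yl in place of 4-methoxy-6-(methylsulfanyl)pyrimidin-2-yl on an amide-type nitrogen gives a number 2.5 percentage points higher from compound 1 to compound 4 (within the scatter) and so does not separate the two compounds at the one concentration tested. This position therefore accepts the exchange of these two substituted pyrimidines with no difference that stands out from repeated measurement. Nothing available explains this outcome.

The compounds shown leave open whether a phenyl ring or a longer alkyl chain in place of the whole pyrimidin-2-yl group on this nitrogen would give a step beyond the scatter. They also leave open what an amine or a carboxylic acid in place of the hydroxy group of compound 4 would do.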